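The source may hold more compounds than are shown below. What is called first, only, known or untested is meant among the compounds shown, and "the series" means these compounds.

Values in a functional assay on MCF7 cells (Homo sapiens) for antiproliferative activity (a higher number here means a weaker inhibitor, a lower number a stronger inhibitor), so far
compound 1 `CC(C)=CCc1cc(C(=O)Nc2cc3ccc(OCCC4CCCCN4)c(C)c3oc2=O)ccc1O` gives 710 nM
compound 2 `CCCNCCCOc1ccc2cc(NC(=O)c3ccc(O)c(CC=C(C)C)c3)c(=O)oc2c1C` gives 980 nM
compound 3 `CC(C)=CCc1cc(C(=O)Nc2cc3ccc(OCCCNC(C)(C)C)c(C)c3oc2=O)ccc1O` gives 950 nM

Compound 3 lies within the scatter of both compound 1 and compound 2, so the three sit at one level. Compound 4 `COC(=O)CNCCCOc1ccc2cc(NC(=O)c3ccc(O)c(CC=C(C)C)c3)c(=O)oc2c1C` is next, with (methoxycarbonyl)methyl in place of tert-butyl on an amine nitrogen. The closest measured change, at that same nitrogen, is a 1.0-fold lower number from compound 2 to compound 3 (0.01 log units; within the scatter) and it stays within the scatter. Changes to the whole amine end gave a 1.4-fold higher number from compound 1 to compound 2 (0.14 log units; within the scatter) and a 1.3-fold higher number from compound 1 to compound 3 (0.13 log units; within the scatter) with the same outcome. Within the data shown here, no measured compound carries (methoxycarbonyl)methyl, so the range is kept wide. Going by compound 3 at 950 nM and these steps, no step beyond the scatter is expected in this assay for the new group. The estimated step is a 1.2-fold higher number from compound 3 to compound 4 (0.06 log units; within the scatter) and it rests on three compounds only. For compound 4 the estimated value is 1100 nM with an expected range from 500 nM to 2800 nM in this read-out.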

Compound 4, half-maximal inhibitory concentration: 2820 nM
Compound 4: the middle estimate sits 2.6-fold (0.41 log units) below what was measured; the whole stated range lies below it.
By their numbers in this assay, from the lowest: compounds 1, 3 and 2 (each within the scatter of the next); then compound 4.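

In this assay, the substituent on the amine nitrogen now makes a difference beyond the scatter: (methoxycarbonyl)methyl in place of tert-butyl gives a 3.0-fold higher number from compound 3 to compound 4 (0.47 log units; beyond the scatter), and the comparison with the propyl group gives a 2.9-fold higher number from compound 2 to compound 4 (0.46 log units; beyond the scatter), although propyl and tert-butyl themselves stay within the scatter of each other. Replacing the piperidin-2-yl end gives a 4.0-fold higher number from compound 1 to compound 4 (0.60 log units; beyond the scatter), so of the amine ends shown, only the one carrying (methoxycarbonyl)methyl separates from the level of the other three compounds. Nothing available accounts for this shift.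

On these data alone, it remains open whether the higher number follows the methoxycarbonyl group specifically or oxygen-bearing groups on this nitrogen more generally. A carboxylic acid, a primary amide or a 2-methoxyethyl group at the same nitrogen would help separate these readings.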